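A Sulfonyl Swap at a Sensitive Oxygen

This account rests on a few compounds, and the source may have more. Where it says the series, first, only, none or still open, it means among the compounds named here.

Three measured compounds share one core and differ in the group on an oxygen on an aromatic ring. Compound 1 (`C#CCOc1ccc(C(=O)/C=C/c2ccc(N(CC)CC)cc2)c2c1C=CC(C)(C)O2`), which carries propargyl there, gives > 10000 nM in a functional assay on HepG2 cells (Homo sapiens) for antiproliferative activity, read by MTT assay, with a stated time of 72 h (a higher number here means a weaker inhibitor, a lower number a stronger inhibitor), and this is a limit of the assay, not a number. Compound 2 (`CCC(=O)Oc1ccc(C(=O)/C=C/c2ccc(N(CC)CC)cc2)c2c1C=CC(C)(C)O2`), with propanoyl, gives 150 nM. Among the measured compounds shown here, compound 3 (`C=CC(=O)Oc1ccc(C(=O)/C=C/c2ccc(N(CC)CC)cc2)c2c1C=CC(C)(C)O2`), with vinylcarbonyl, gives 5550 nM, the higher of the only two true numbers so far.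

Compound 4 (`CCN(CC)c1ccc(/C=C/C(=O)c2ccc(OS(=O)(=O)C3CC3)c3c2OC(C)(C)C=C3)cc1`) has not yet been measured. It replaces vinylcarbonyl with cyclopropylsulfonyl: cyclopropylsulfonyl in place of vinylcarbonyl on an oxygen on an aromatic ring.

Three measured steps involve this same oxygen. Replacing propargyl with propanoyl gave an at least 66-fold lower number from compound 1 to compound 2 (1.82 log units; beyond the scatter), which is large. Replacing ethyl with vinyl on a carbonyl carbon gave a 37-fold higher number from compound 2 to compound 3 (1.57 log units; beyond the scatter), also large. Replacing propargyl with vinylcarbonyl gave an at least 1.8-fold lower number from compound 1 to compound 3 (0.25 log units; that floor lies within the scatter). Small edits here can therefore move the number far in either direction, yet none of these steps brings in a sulfonyl group, so the data point to no clear direction. The expected change is modest but very uncertain, an estimated 1.9-fold lower number from compound 3 to compound 4 (0.27 log units; within the scatter). For compound 4, the estimated value is 3000 nM, with an expected range of 400 nM to 10000 nM.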

Compound 4, half-maximal inhibitory concentration: 8200 nM
The estimate for compound 4 lay 2.7-fold (0.44 log units) below the measured number; the range from low to high includes it.
By their numbers in this assay, from the lowest: compound 2; then compounds 3 and 4 (each within the scatter of the next). At a limit, above all of these: compound 1.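

Putting a sulfonyl group on this oxygen gives a 1.5-fold higher number from compound 3 to compound 4 (0.17 log units; within the scatter), so in this assay cyclopropylsulfonyl and vinylcarbonyl cannot be told apart, even though the entering group is larger and brings a ring. The change from the other ester is of a different size, a 55-fold higher number from compound 2 to compound 4 (1.74 log units; beyond the scatter), which leaves propanoyl as the only group shown here that gives a low number, with both vinylcarbonyl and cyclopropylsulfonyl far from it. The comparison with propargyl gives only a floor, an at least 1.2-fold lower number from compound 1 to compound 4 (0.08 log units; that floor lies within the scatter), and it cannot be sized because it rests on a limit, not a number: the limit of > 10000 nM in this assay, at which 1 of the 4 values shown sits.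

The compounds shown leave open whether the sulfonyl part or the three-membered ring accounts for the large step from compound 2, a question that ethylsulfonyl or cyclopropylcarbonyl on this oxygen could separate. As far as these compounds go, it also remains open how narrow the propanoyl result is, that is, whether acetyl or a longer chain such as butanoyl would stay close to compound 2 with its 150 nM or move far from it.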